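One inverted sugar carbon in a cell growth inhibitor

The source may hold more compounds than are shown below. What is called first, only, known or untested is meant among the compounds shown, and "the series" means these compounds.

Measured so far:
compound 1 `C[C@@H]1O[C@H](N2C(=O)/C(=C3\Nc4ccccc4C3=O)c3ccccc32)[C@H](O)[C@H](O)[C@H]1O` — 670 nM
compound 2 `O=C1/C(=C2/C(=O)N([C@@H]3O[C@H](CO)[C@H](O)[C@H](O)[C@H]3O)c3ccccc32)Nc2ccccc21` — 25800 nM

Of the compounds shown here, two have been tested in a functional assay on MCF7 cells (Homo sapiens) for inhibition; on this read-out lower numbers stand for stronger inhibition and higher numbers for weaker inhibition. Compound 1 gives 670 nM, the lowest of the two numbers. Going by the values given here, compound 2 gives 25800 nM; the gap between these two lies beyond the scatter of the assay, and since no single structural step connects them, only the two values themselves speak.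

The step followed here leads from compound 1 to compound 3 `C[C@@H]1O[C@@H](N2C(=O)/C(=C3\Nc4ccccc4C3=O)c3ccccc32)[C@H](O)[C@H](O)[C@H]1O`, which has not yet been measured. The difference is the two compounds have the same atoms and bonds and differ only in configuration as drawn: 1 of 6 stereo elements differ; a stereocentre at a saturated ring carbon is drawn S in compound 1 and R in compound 3. Inverting one such centre can leave the number where it is or move it a long way, and no measured pair here shows which way it goes. The step from compound 1 to compound 3 is expected to be a 3.7-fold higher number from compound 1 to compound 3 (0.57 log units; beyond the scatter), toward weaker inhibition. Compound 3 is therefore estimated at about 2500 nM, within 400 nM to 15000 nM.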

Compound 3, half-maximal inhibitory concentration: 760 nM
Compound 3: the middle estimate sits 3.3-fold (0.52 log units) above what was measured; the measured number falls inside the stated range.
By their numbers in this assay, from the lowest: compounds 1 and 3 (each within the scatter of the next); then compound 2.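

In this assay, inverting this one saturated ring carbon gives a 1.1-fold higher number from compound 1 to compound 3 (0.05 log units; within the scatter), so at this position the S and R drawings cannot be told apart by this read-out. This is the first comparison here in which only one place differs, which makes it a clean test of the centre: the fact that compounds 1 and 3 differ only in the configuration as drawn

For this core and this sugar, then, either configuration at this carbon is compatible with inhibition in these cells, a finding that applies to this one pair only.

As far as these compounds go, the other stereocentres of the sugar remain untested, so it is unknown whether inverting any of them would matter as little. Also open, from the compounds shown here alone, is what would happen if a carboxylic acid, an amine or a longer chain replaced the methyl group of compound 1, and compound 2 differs from compound 1 in more than one place, so its much higher number cannot be assigned to any single feature.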